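Phenyl in place of pentyl on the chain of compound 2

The source may report more compounds than this note shows. Statements on the series, on what has been measured and on what is new or still open speak of the compounds shown alone.

Measured in a physicochemical assay for lipophilicity; a lower number here means a more polar compound, a higher number a more lipophilic compound:
Compound 1 `CCCCCc1nc2ccccc2[nH]1`: 3.43
Compound 2 `CCCCCCCCc1nc2ccccc2[nH]1`: 4.93

Compound 2 holds the higher of the two numbers in this assay. Going by the values given here, the one measured step shows a number 1.50 log units higher from compound 1 to compound 2 (beyond the scatter). That step is propyl in place of hydrogen on a saturated chain carbon, five bonds along the chain from an aromatic carbon.

Compound 3 `c1ccc(CCCc2nc3ccccc3[nH]2)cc1` carries phenyl in place of pentyl on a saturated chain carbon, three bonds along the chain from an aromatic carbon. Among the compounds with values here, the measured step bears on the pentyl that leaves, but no measured step shows what phenyl does. A fall somewhat smaller than that step is therefore expected, and the expected change is a number 1.03 log units lower from compound 2 to compound 3 (beyond the scatter). Compound 3 is estimated at 3.9, with an expected range from 3.5 to 4.3.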

Compound 3, partition coefficient: 4.46
Estimate against measurement, compound 3: 0.56 log units below, and the stated range ends below it.
By their numbers in this assay, from the lowest: compound 1; then compound 3; then compound 2.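

In this assay, phenyl in place of pentyl on a saturated chain carbon, three bonds along the chain from an aromatic carbon, gives a number 0.47 log units lower from compound 2 to compound 3 (beyond the scatter), the first measured fall among these compounds. Phenyl in place of ethyl at the same place gives a number 1.03 log units higher from compound 1 to compound 3 (beyond the scatter), so compound 3 lies between the two compounds with plain alkyl chains and nearer to compound 2. Nothing on hand explains why phenyl lands at this point on the scale.

From the compounds shown here alone, whether a saturated ring such as cyclohexyl would give a similar number in place of pentyl remains open. So does the effect of an amine or a carboxylic acid on the phenyl ring of compound 3, or of a longer chain between that ring and the shared core.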